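The source may report more compounds than this note shows. Statements on the series, on what has been measured and on what is new or still open speak of the compounds shown alone.

Compound 2 `COc1ccc(-c2cc(=O)c3c(OC)cc(OC)cc3n2S(=O)(=O)c2cccc(Br)c2)cc1` reaches in a functional assay on HepG2 cells (Homo sapiens) for antiproliferative activity, with a stated time of 72 h (on this read-out lower numbers stand for an effect already at smaller amounts and higher numbers for an effect only at larger amounts of compound), only a limit, > 58600 nM. Compound 1 `COc1ccc(-c2cc(=O)c3c(OC)cc(OC)cc3n2S(=O)(=O)c2ccc(F)cc2)cc1` likewise stops at a limit in this assay, > 65500 nM. The step that the two limits leave unreadable from compound 1 to compound 2 cannot be read, since the limit of > 58600 nM in this assay, at which 1 of the 2 values shown sits, and the limit of > 65500 nM in this assay, at which 1 of the 2 values shown sits, are both limits rather than numbers. Compound 3 `COc1ccc(-c2cc(=O)c3c(OC)cc(OC)cc3n2S(=O)(=O)c2ccc(OC)cc2)cc1` differs from compound 2 by 4-methoxyphenyl in place of 3-bromophenyl on a sulfonyl sulfur. Among the compounds with values here, no measured step in this assay gives a direction or a size for such a change; both known points sit at limits. Compound 3 is expected to stay at a limit too, estimated at 100000 nM with a range from 50000 nM to 300000 nM. The step that the limit leaves unreadable from compound 2 to compound 3 is thus an expectation only, with no readable size.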

Compound 3, half-maximal effective concentration: > 82700 nM
Compound 3: only a limit was reported; the forecaster's own chance of this, stated with the estimate: 85%; the middle value does not contradict the limit.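

Within the data shown here, compound 3 also reaches only a limit, > 82700 nM, so no step among compound 1, compound 2 and compound 3 can be read. The compounds shown leave open whether any group on the sulfonyl sulfur gives a readable value in this assay.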